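Dithiocarbamate chromone series: amine swap on the thiocarbonyl

The compounds below may be only part of what the source reports. "The series", "measured", "known", "first", "only" and "open" are said of these compounds alone.

Two compounds of the series have numbers in a functional assay on HEp-2 cells (Homo sapiens) for antiproliferative activity, read by MTT assay, with a stated time of 72 h; on this read-out lower numbers stand for stronger inhibition and higher numbers for weaker inhibition. Compound 1 `COc1ccc2occ(CSC(=S)N(C(C)C)C(C)C)c(=O)c2c1` carries the dithiocarbamate side chain on a different position of the shared core than compound 2 does; in this assay compound 1 gives 8900 nM. Compound 2 `COc1ccc2oc(CSC(=S)N3CCCCC3)cc(=O)c2c1` gives 1500 nM, the lowest of the two numbers; the number of compound 1 stands higher, and that gap lies beyond the usual scatter. Among the measured compounds shown here, no pair of the measured compounds differs in only one place, so no single step has been isolated so far.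

Compound 3 `COc1ccc2oc(CSC(=S)N3CCOCC3)cc(=O)c2c1` is not yet measured. It differs from compound 2 in one place: morpholin-4-yl in place of piperidin-1-yl on a thiocarbonyl carbon. The two rings have the same size and the same count of heavy atoms; the entering ring brings one hydrogen-bond acceptor where the leaving ring had none. Nothing in the measured pair speaks to this exchange, so the step is expected to be small, if anything toward a slightly higher number, and most likely within the scatter. On that basis compound 3 is expected to give 2200 nM, with a range from 900 nM to 6000 nM. The expected step from compound 2 to compound 3 is a 1.5-fold higher number from compound 2 to compound 3 (0.17 log units; within the scatter).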

Compound 3, half-maximal inhibitory concentration: 3000 nM
For compound 3 the middle estimate is 1.4-fold (0.13 log units) below the measured one; low and high end bracket the measured number.
By their numbers in this assay, from the lowest: compounds 2 and 3 (each within the scatter of the next); then compound 1.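

In this assay, the series now has its first step in a single place, the swap of piperidin-1-yl for morpholin-4-yl on a thiocarbonyl carbon (a 2.0-fold higher number from compound 2 to compound 3 (0.30 log units; within the scatter)). The two measured compounds could not separate the amine from the attachment point of the side chain, whereas this pair holds the core and the attachment point fixed and shows that replacing a ring carbon with oxygen, adding one hydrogen-bond acceptor in a ring of the same size, does not move the number beyond the scatter, so compound 2 and compound 3 cannot be told apart in this read-out. No measurement shown here gives any property of these two rings that could bear on this result.

On these data alone, it remains open whether a ring with a basic second nitrogen, such as 4-methylpiperazin-1-yl, or a smaller ring, such as pyrrolidin-1-yl, would stay as close to compound 2 on the same thiocarbonyl carbon. As far as these compounds go, the separate contributions of the amine and the side-chain position to the gap between compound 1 and compound 2 also remain open, since those two compounds differ in more than one place.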